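Prenyl chain extension on the core of compound 1

This account rests on a few compounds, and the source may have more. Where it says the series, first, only, none or still open, it means among the compounds named here.

Measured so far:
compound 1 `CC(C)=CCC1Cc2c(OCCCNS(=O)(=O)c3ccc(Br)cc3)cc(=O)n(CCCO)c2CC1(C)C`: 19.5%
compound 2 `CC(C)=CCC1Cc2c(OCCCOc3ccc(Cl)cc3)cc(=O)n(CCCO)c2CC1(C)C`: 22.7%
compound 3 `CC(C)=CCC1Cc2c(OCCCOc3ccc([N+](=O)[O-])cc3)cc(=O)n(CCCO)c2CC1(C)C`: 47.5%

In a functional assay on PANC-1 cells (Homo sapiens) for inhibition, read by MTT assay, with a stated time of 24 h, tested at 10 uM (on this read-out higher numbers stand for more inhibition at the one concentration tested (going by the name of the read-out) and lower numbers for less inhibition), compound 1 gives the lowest of the three numbers; compound 2 is nearest, a number 3.2 percentage points higher from compound 1 to compound 2 (within the scatter), and compound 3 furthest, a number 28 percentage points higher from compound 1 to compound 3 (beyond the scatter). The remaining measured step is a number 24.8 percentage points higher from compound 2 to compound 3 (beyond the scatter). Compound 4 `CC(C)=CCC/C(C)=C/CC1Cc2c(OCCCNS(=O)(=O)c3ccc(Br)cc3)cc(=O)n(CCCO)c2CC1(C)C` differs from compound 1 by one change: 3-methylbut-2-en-1-yl in place of hydrogen on a saturated chain carbon bound to a double-bonded chain carbon. Cut one bond further out, this reads 3-methylbut-2-en-1-yl to 3,7-dimethylocta-2,6-dien-1-yl. Within the data shown here, the three measured steps concern the 4-chlorophenoxy, 4-nitrophenoxy and ((4-bromophenyl)sulfonyl)amino groups and the nitro-for-chloro exchange; none touches the part altered here, so no measured step bears on this change. No shift beyond the scatter is therefore expected in this assay, in either direction. Compound 4 is estimated at 22% (range 8% to 38%), an expected step of a number 2.5 percentage points higher from compound 1 to compound 4 (within the scatter).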

Compound 4, a percentage reported as inhibition, at one concentration (the size of the read-out at that concentration, not a potency): 15.2%
Estimate against measurement, compound 4: 6.8 percentage points above; low and high end bracket the measured number.
By their numbers in this assay, from the lowest: compounds 4, 1 and 2 (each within the scatter of the next); then compound 3.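

In this assay, the step from 3-methylbut-2-en-1-yl to 3,7-dimethylocta-2,6-dien-1-yl is a number 4.3 percentage points lower from compound 1 to compound 4 (within the scatter), so this position on the core of compound 1 accepts the longer chain with no shift that can be told from the scatter. Among these compounds, the earlier steps all lie in the chain carrying the 4-chlorophenoxy, 4-nitrophenoxy and ((4-bromophenyl)sulfonyl)amino groups, so this is the only reading on the prenyl position. No evidence at hand accounts for this result. As far as these compounds go, whether the longer chain behaves the same way alongside the 4-nitrophenoxy group of compound 3 stays open, as does the effect of an amine or a carboxylic acid at this position.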